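The source may report more compounds than this note shows. Statements on the series, on what has been measured and on what is new or still open speak of the compounds shown alone.

Measured so far:
- compound 1, `COc1cc(/C=C/COC(C)=O)ccc1OC(C)=O`: 9710 nM
- compound 2, `CC[C@H](C)C(=O)Oc1ccc(/C=C/COC(C)=O)cc1OC`: 12900 nM

In a functional assay on U-251 cells (Homo sapiens) for antiproliferative activity, read by sulforhodamine B assay, with a stated time of 72 h (a higher number here means a weaker inhibitor, a lower number a stronger inhibitor), compound 1 stands at the lowest of the two numbers; its nearest neighbour is compound 2, and a 1.3-fold higher number from compound 1 to compound 2 (0.12 log units; within the scatter) lies within the scatter, so the two cannot be ordered.

Compound 3, `CC[C@H](C)C(=O)OC/C=C/c1ccc(OC(C)=O)c(OC)c1`, differs from compound 1 as follows: sec-butyl in place of methyl on a carbonyl carbon. Within the data shown here, the only step that bears on this is the one that makes the same exchange at a different carbonyl carbon of compound 1, namely a 1.3-fold higher number from compound 1 to compound 2 (0.12 log units; within the scatter), which did not move the number beyond the scatter. Among the measured compounds shown here, no other step is known. The expectation for this assay is therefore a step of about the same size, a 1.2-fold higher number from compound 1 to compound 3 (0.07 log units; within the scatter), with no change beyond the scatter claimed. Compound 3 is estimated at 11500 nM, within a range of 5500 nM to 24000 nM.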

Compound 3, half-maximal inhibitory concentration: 28100 nM
Compound 3: the middle estimate sits 2.4-fold (0.39 log units) below what was measured; the measured number lies above the stated range.
By their numbers in this assay, from the lowest: compounds 1 and 2 (each within the scatter of the next); then compound 3.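

In this assay the record is a 2.9-fold higher number from compound 1 to compound 3 (0.46 log units; beyond the scatter) for sec-butyl in place of methyl on this carbonyl carbon, so this exchange does not leave the number within the scatter at every site. The same exchange at the other acetyl, which compound 3 retains, gives a 1.3-fold higher number from compound 1 to compound 2 (0.12 log units; within the scatter) and stays within the scatter, so in this pair of steps the outcome depends on which carbonyl carbon carries the change, although each site rests on a single step. No measured evidence on hand accounts for the difference between the two sites.

Going by these compounds, with only methyl and sec-butyl on this carbonyl carbon, it remains open whether the number climbs steadily with group size or whether the branching matters, which a straight butyl chain or a longer chain such as hexyl would test. Also open, on these data alone, is how this site responds to a group of another kind, such as an amine or a carboxylic acid at the end of the chain.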